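Swapping the ester around on the piperazine core

The source may report more compounds than this note shows. Statements on the series, on what has been measured and on what is new or still open speak of the compounds shown alone.

Three compounds from this series have been run in an ADME assay on a cell-free system (plasma, Rattus norvegicus, strain Sprague-Dawley) for metabolic stability, read by LC-MS, tested at 1 uM; a lower number here means that the compound disappears faster, a higher number that the compound lasts longer. Compound 1 `CCOC(=O)C1CN(S(=O)(=O)c2ccc(F)cc2)CCN1C(C)=O` carries an ethoxycarbonyl group on the core and gives 0.617 h in this assay. Compound 3 `CCOC(=O)C1CN(C(C)=O)CCN1S(=O)(=O)c1ccc(F)cc1` places the same group at the other saturated ring carbon and gives 0.35 h. Compound 2 `CC(=O)N1CCN(S(=O)(=O)c2ccc(F)cc2)C(CO)C1`, which bears a hydroxymethyl group instead, reaches only the limit of the assay, >= 4 h, which is a limit and not a number (the limit of >= 4 h in this assay, at which 1 of the 3 values shown sits). Among the two numbers shown, compound 1 stands highest, with compound 3 nearest; the gap between them is within the scatter. Among the measured compounds shown here, the one step that differs in a single place, an at least 11-fold lower number from compound 2 to compound 3 (1.05 log units; beyond the scatter), was large and beyond the scatter.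

Compound 4 `CC(=O)OCC1CN(S(=O)(=O)c2ccc(F)cc2)CCN1C(C)=O` is not yet measured. It differs from compound 1 by acetoxymethyl in place of ethoxycarbonyl on a saturated ring carbon. The structural change keeps an ester on the core, as compound 1 has, and moves away from nothing that resembles the hydroxymethyl of compound 2, so no step shown points toward the long half-life of compound 2. Compound 4 is therefore expected to sit close to compound 1, with a step of a 1.2-fold lower number from compound 1 to compound 4 (0.09 log units; within the scatter) that stays within the scatter. Compound 4 is estimated at 0.5 h, with a range from 0.15 h to 1.6 h.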

Compound 4, half-life: 0.5 h
Compound 4: middle estimate and measured number agree at the digits printed, within the range that was stated.
By their numbers in this assay, from the lowest: compounds 3, 4 and 1 (each within the scatter of the next). At a limit, above all of these: compound 2.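

In this assay, the step of a 1.2-fold lower number from compound 1 to compound 4 (0.09 log units; within the scatter) shows that acetoxymethyl can take the place of ethoxycarbonyl on this saturated ring carbon with no change that stands out from the scatter. Until now, ethoxycarbonyl was the only group shown at this place, next to the ring atom that bears an acetyl group, so this is the first comparison of two groups there; the two match in what is counted for them, with the same heavy atoms and the same hydrogen-bond acceptors, but they are joined differently. Nothing measured here bears on why two groups joined so differently give numbers this close.

The compounds shown leave open how a hydroxymethyl group would read at this same place, since the one compound that carries it, compound 2, has its group on the other saturated ring carbon and gives only a limit of the assay. They also leave open what a carboxylic acid, an aminomethyl group or a longer ester chain would give at this place in this assay.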